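One Methoxy Removed: Reading an Unmeasured Analogue from a Precedent

The source may hold more compounds than are shown below. What is called first, only, known or untested is meant among the compounds shown, and "the series" means these compounds.

In a functional assay on DU-145 cells (Homo sapiens) for antiproliferative activity, read by MTT assay, with a stated time of 24 h (a higher number here means a weaker inhibitor, a lower number a stronger inhibitor), three compounds have been measured:

compound 1 `COc1ccc(-c2cc(C(=O)/C=C/c3ccccc3)nc3cc(-c4ccccc4)nn23)cc1OC` gives 15600 nM;
compound 2 `COc1ccc(/C=C/C(=O)c2cc(-c3ccc(OC)c(OC)c3)n3nc(-c4ccccc4)cc3n2)cc1` gives 14900 nM;
compound 3 `COc1ccc(C(=O)/C=C/c2cc(-c3ccc(OC)cc3)n3nc(-c4ccccc4)cc3n2)cc1` gives 8500 nM.

Compound 3 has the lowest number of the three, yet its gaps to compound 2 and to compound 1 both lie within the scatter, so the three cannot be ordered. The untested compound 4 `COc1ccc(-c2cc(/C=C/C(=O)c3ccccc3)nc3cc(-c4ccccc4)nn23)cc1` arises from compound 3 by one change, (hydrogen in place of methoxy on an aromatic carbon). The same change connects compound 2 to compound 1, (hydrogen in place of methoxy on an aromatic carbon), and there it made a step of a 1.0-fold higher number from compound 2 to compound 1 (0.02 log units; within the scatter). The place of the change is described in the same words for both pairs. The cores of compound 3 and compound 2 differ in a way that is not broken down here.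

Compound 4 is therefore expected to sit close to compound 3, with an estimated step of a 1.1-fold higher number from compound 3 to compound 4 (0.02 log units; within the scatter), because the earlier step of a 1.0-fold higher number from compound 2 to compound 1 (0.02 log units; within the scatter) stayed flat. The estimate for compound 4 in this assay is 9000 nM, expected to fall between 4500 nM and 18000 nM.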

Compound 4, half-maximal inhibitory concentration: 13700 nM
Compound 4: middle estimate off by 1.5-fold (0.18 log units), on the low side, and the stated range covers the measured number.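

Replacing methoxy with hydrogen on the aromatic carbon para to a large group gives, in this assay, a step of a 1.6-fold higher number from compound 3 to compound 4 (0.21 log units; within the scatter), so this pair cannot be read as a real difference in the measured number. Set beside the earlier pair, the change behaves alike on the two cores as far as these measurements can tell: the same change on two cores in this assay, a 1.0-fold higher number (0.02 log units; within the scatter) from compound 2 to compound 1 and a 1.6-fold higher number (0.21 log units; within the scatter) from compound 3 to compound 4, 1.5-fold (0.19 log units) apart, within the scatter of two such steps This shows that neither core gives a readable effect for this swap in this assay, but two small steps cannot establish that the swap will stay flat on every core in the series, nor can they explain why it does.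

The compounds shown leave open whether a different group on that same aromatic carbon, such as an amine or a carboxylic acid, would give a step beyond the scatter. In the two pairs compared here, only methoxy and hydrogen appear at that place, so how far the number can move there remains an open question.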